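Replacing 4-methylphenyl with 2-chloro-6-fluorophenyl

The source may hold more compounds than are shown below. What is called first, only, known or untested is meant among the compounds shown, and "the series" means these compounds.

In a functional assay on cells (Tumor Cell line, Homo sapiens) for cytotoxicity (on this read-out lower numbers stand for stronger inhibition and higher numbers for weaker inhibition), compound 1 (`CN(C)Cc1cc(C(=O)/C=C/c2ccccc2Cl)cc(CN(C)C)c1O`) gives 9550 nM and compound 2 (`Cc1ccc(/C=C/C(=O)c2cc(CN(C)C)c(O)c(CN(C)C)c2)cc1`) gives 17800 nM. With only these two compounds measured, compound 2 stands within the scatter of compound 1, so the pair is not separated on this read-out.

Compound 3 (`CN(C)Cc1cc(C(=O)/C=C/c2c(F)cccc2Cl)cc(CN(C)C)c1O`) keeps the shared core and differs from compound 2 in one group: 2-chloro-6-fluorophenyl in place of 4-methylphenyl on a double-bonded chain carbon bound to a double-bonded chain carbon. For the measured compounds named here, the entering 2-chloro-6-fluorophenyl group resembles the 2-chlorophenyl group of compound 1, but it also holds a fluorine that no measured compound carries.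

Going by the values given here, one measured step bears on this change. It exchanges 2-chlorophenyl for 4-methylphenyl at the same place and amounts to a 1.9-fold higher number from compound 1 to compound 2 (0.27 log units; within the scatter). That step gives no sign of a large response to this exchange, although it says nothing directly about the added fluorine. No change beyond the scatter is therefore expected, and the expected step is a 1.8-fold lower number from compound 2 to compound 3 (0.25 log units; within the scatter). Compound 3 is estimated at 10000 nM, with an expected range of 4000 nM to 25000 nM.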

Compound 3, half-maximal inhibitory concentration: 9120 nM
Compound 3: the middle estimate sits 1.1-fold (0.04 log units) above what was measured; measured number inside the range.
By their numbers in this assay, from the lowest: compounds 3, 1 and 2 (each within the scatter of the next).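

In this assay, fluoro in place of hydrogen on an aromatic carbon amounts to a 1.0-fold lower number from compound 1 to compound 3 (0.02 log units; within the scatter), so the added fluorine, on which the earlier step could say nothing directly, does not separate these two compounds on this read-out. The full exchange of 4-methylphenyl for 2-chloro-6-fluorophenyl on a double-bonded chain carbon bound to a double-bonded chain carbon amounts to a 2.0-fold lower number from compound 2 to compound 3 (0.29 log units; within the scatter), which means that none of the three groups now seen at this place stands apart from the others. No measurement is available that would account for this flat response at the position.

From the compounds shown here alone, all three groups at this place are phenyl rings carrying only methyl, chlorine or fluorine, so it remains open whether a carboxylic acid, an amine or a methoxy group there would move the number beyond the scatter. Going by these compounds, all three compounds also share the same core, so the response to changes anywhere else in the structure remains open as well.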